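Nitro for Chloro on the Anilino Ring of Compound 3

This account rests on a few compounds, and the source may have more. Where it says the series, first, only, none or still open, it means among the compounds named here.

Of the compounds shown here, three built on one shared core have been tested in a functional assay on MGC-803 cells (Homo sapiens) for cytotoxicity, read by MTT assay, with a stated time of 72 h; a lower number here means a stronger inhibitor, a higher number a weaker inhibitor. Compound 1 `FC(F)(F)c1ccc(CSc2nc(N3CCCCC3)c3ccccc3n2)cc1` gives 18600 nM. Compound 2 `FC(F)(F)c1ccc(CSc2nc(Nc3cccc(C(F)(F)F)c3)c3ccccc3n2)cc1` gives 15100 nM, and compound 3 `FC(F)(F)c1ccc(CSc2nc(Nc3cccc(Cl)c3)c3ccccc3n2)cc1` gives 14600 nM. Compound 3 holds the lowest of the three numbers, but its neighbours lie close: a 1.0-fold lower number from compound 2 to compound 3 (0.01 log units; within the scatter), and a 1.3-fold lower number from compound 1 to compound 3 (0.11 log units; within the scatter), so none of the three can be set apart from the others.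

Compound 4 `O=[N+]([O-])c1cccc(Nc2nc(SCc3ccc(C(F)(F)F)cc3)nc3ccccc23)c1` has not yet been measured. It differs from compound 3 in one place: nitro in place of chloro on an aromatic carbon. Among the compounds with values here, no measured step swaps chloro for nitro directly, so the closest guide is the step that exchanged one group for another at the same place, a 1.0-fold lower number from compound 2 to compound 3 (0.01 log units; within the scatter), together with a 1.2-fold lower number from compound 1 to compound 2 (0.09 log units; within the scatter), where a wholly different group took the same position. Both of those changes left this assay essentially unmoved.

On that basis the change from chloro to nitro is expected to stay within the scatter as well, giving an estimated 1.0-fold lower number from compound 3 to compound 4 (0.02 log units; within the scatter). Compound 4 is therefore expected to show about 14000 nM, with a plausible range from 6000 nM to 32000 nM.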

Compound 4, half-maximal inhibitory concentration: > 50000 nM
Compound 4 ended at the assay's limit; the forecaster's own chance of this, stated with the estimate: 10%; middle value at least 3.5-fold (0.55 log units) from the limit.
By their numbers in this assay, from the lowest: compounds 3, 2 and 1 (each within the scatter of the next). At a limit, above all of these: compound 4.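

In this assay compound 4 gives > 50000 nM, which is a limit of the assay and not a number, the only such case among these compounds: the limit of > 50000 nM in this assay, at which 1 of the 4 values shown sits. Earlier exchanges at this place left the number essentially unmoved, as with a 1.0-fold lower number from compound 2 to compound 3 (0.01 log units; within the scatter), so the place could have seemed indifferent to what stands on it, but nitro is the first group there to move the number beyond the scatter, with an at least 3.4-fold higher number from compound 3 to compound 4 (0.53 log units; beyond the scatter) and an at least 3.3-fold higher number from compound 2 to compound 4 (0.51 log units; beyond the scatter). The comparison with the piperidin-1-yl compound points the same way, with an at least 2.6-fold higher number from compound 1 to compound 4 (0.42 log units; beyond the scatter), so (3-nitrophenyl)amino is set apart from all three earlier groups, and what stands on this aromatic carbon can matter in this assay.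

Nitro brings more heavy atoms than chloro and also hydrogen-bond acceptors where chloro has none, and a single compound cannot show which of these differences, if either, goes with the higher number. As far as these compounds go, whether a nitrile, a carboxylic acid or an amine on the same carbon would sit with chloro and trifluoromethyl or with nitro remains open, as does the result for nitro on another carbon of that ring.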